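The compounds below may be only part of what the source reports. "The series", "measured", "known", "first", "only" and "open" are said of these compounds alone.

Measured compounds: compound 1 `COc1ccc2[nH]c(-c3ccccc3)c(C=C(C#N)C#N)c2c1` with 2000 nM in a functional assay on A498 cells (Homo sapiens) for inhibition, read by sulforhodamine B assay, with a stated time of 48 h; a higher number here means a weaker inhibitor of growth, a lower number a stronger inhibitor of growth; compound 3 `COc1ccc(-c2[nH]c3ccc(OC)cc3c2C=C(C#N)C#N)cc1` with 75 nM. For compound 2 `COc1ccc(-c2[nH]c3ccc(OC)cc3c2/C=C(\C#N)S(=O)(=O)c2ccccc2)cc1` the entry in this assay reads "not determined" (no result reported).

The change from compound 3 to compound 1, (hydrogen in place of methoxy on an aromatic carbon), gave a 27-fold higher number from compound 3 to compound 1 (1.43 log units; beyond the scatter). Compound 4 `COc1ccc2[nH]c(-c3ccccc3)c(/C=C(\C#N)S(=O)(=O)c3ccccc3)c2c1` is obtained from compound 2 by the same change, (hydrogen in place of methoxy on an aromatic carbon), at the same place. The difference between the cores of compound 2 and compound 3 is not broken down here.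

Compound 2 has no number, so nothing anchors compound 4 directly; the only guide is the large step seen from compound 3 to compound 1, and whether it carries over to the core of compound 2 is not shown. Compound 4 is therefore expected, with wide uncertainty, near 3000 nM, between 500 nM and 20000 nM.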

Compound 4, concentration for 50% growth inhibition: 9300 nM
For compound 4 the middle estimate is 3.1-fold (0.49 log units) below the measured one; the measured number falls inside the stated range.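

No new step can be read for compound 4: compound 2, its partner, offers no number to set against it. Going by these compounds, whether the change from 4-methoxyphenyl to phenyl carries the same size on both cores stays open, and no evidence on the result is available.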